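A few compounds are considered here, and "the series" means these few. Any claim that something is new, unique, unknown or untested is made for them only; others in the source may bear on it.

Measured in a functional assay on DU-145 cells (Homo sapiens) for inhibition, read by trypan blue exclusion, with a stated time of 96 h; a lower number here means a stronger inhibitor of growth, a higher number a weaker inhibitor of growth:

- Compound 1 `Cc1ccc(C)c(/C=C(\C(=O)c2ccc(Cl)cc2)S(=O)(=O)c2ccc(Br)cc2)c1`: 1000 nM
- Compound 2 `Cc1ccc(CS(=O)(=O)/C(=C/c2c(O)cc(O)cc2O)C(=O)c2ccc(Cl)cc2)cc1`: > 100000 nM

Compound 2 stands at a limit in this assay, given as > 100000 nM, and not at a measured number. Compound 3 `Cc1ccc(CS(=O)(=O)/C(=C/c2cc(C)ccc2C)C(=O)c2ccc(Cl)cc2)cc1` differs from it by one change, (2,5-dimethylphenyl in place of 2,4,6-trihydroxyphenyl on a double-bonded chain carbon bound to a double-bonded chain carbon), with 2,5-dimethylphenyl in place of 2,4,6-trihydroxyphenyl on a double-bonded chain carbon bound to a double-bonded chain carbon. Though it differs from compound 3 elsewhere, compound 1 also carries 2,5-dimethylphenyl, and compound 1 gives 1000 nM in this assay. An expected step of an at least 25-fold lower number from compound 2 to compound 3 (1.39 log units; beyond the scatter) therefore points towards stronger inhibition of growth. For compound 3 the estimated value is 4000 nM, with an expected range of 700 nM to 30000 nM.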

Compound 3, concentration for 50% growth inhibition: 1000 nM
Estimate against measurement, compound 3: 4.0-fold (0.60 log units) above; low and high end bracket the measured number.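

In this assay, 2,5-dimethylphenyl in place of 2,4,6-trihydroxyphenyl on a double-bonded chain carbon bound to a double-bonded chain carbon gives an at least 100-fold lower number from compound 2 to compound 3 (2.00 log units; beyond the scatter), so the read-out at this position clearly separates these two groups. Going by these compounds, compound 2 stands at a limit and not at a number, so the full size of this step stays unknown: the limit of > 100000 nM in this assay, at which 1 of the 3 values shown sits. With 2,5-dimethylphenyl kept, 4-methylbenzyl in place of 4-bromophenyl on a sulfonyl sulfur gives no change at the digits printed from compound 1 to compound 3 (within the scatter).

On these data alone, whether a phenyl carrying a single hydroxyl, an amine or a carboxylic acid at this position would read nearer compound 2 or compound 3 stays open.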